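Metabolic stability in the series: from compound 3 to compound 4

The compounds below may be only part of what the source reports. "The series", "measured", "known", "first", "only" and "open" are said of these compounds alone.

Measured compounds in an ADME assay on microsomes from liver (Homo sapiens) for metabolic stability; a lower number here means that the compound disappears faster, a higher number that the compound lasts longer:
- compound 1 `CC#C[C@@H](Cc1nnn[nH]1)c1ccc(OCc2ccc3scc(-c4cncnc4C)c3c2)cc1`: 0.233 h
- compound 2 `CC#C[C@@H](Cc1nnn[nH]1)c1ccc(OCc2cc(F)c3scc(-c4ccc(OC)cc4C)c3c2)cc1`: 0.5 h
- compound 3 `CC#C[C@@H](Cc1nnn[nH]1)c1ccc(OCc2ccc3scc(-c4cc(OCCOC)ccc4C)c3c2)cc1`: 0.867 h

Compound 3 holds the highest number of the three; compound 2 sits within the scatter of it, while compound 1 lies beyond it, with a 3.7-fold higher number from compound 1 to compound 3 (0.57 log units; beyond the scatter).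

Compound 4 `CC#C[C@@H](Cc1nnn[nH]1)c1ccc(OCc2ccc3scc(C4CCCCC4)c3c2)cc1` differs from compound 3 by cyclohexyl in place of 5-(2-methoxyethoxy)-2-methylphenyl on an aromatic carbon. Within the data shown here, the one measured step, from compound 1 to compound 3, swaps one aromatic ring for another and so bears only loosely on a change to a non-aromatic ring; no measured pair exchanges an aromatic ring for a cyclohexyl. The expectation therefore rests on the spread of the three numbers, and a step of a 1.7-fold lower number from compound 3 to compound 4 (0.24 log units; within the scatter) in this assay is estimated, i.e. a somewhat lower number that may still fall within the scatter. For compound 4 the estimate is 0.5 h, with a range from 0.2 h to 1.2 h.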

Compound 4, half-life: 0.183 h
Compound 4: middle estimate off by 2.7-fold (0.44 log units), on the high side; the measured number lies below the stated range.
By their numbers in this assay, from the lowest: compounds 4 and 1 (each within the scatter of the next); then compounds 2 and 3 (each within the scatter of the next).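

In this assay the aromatic carbon two ring bonds from the ring sulfur now carries a non-aromatic ring, and cyclohexyl gives a 4.7-fold lower number from compound 3 to compound 4 (0.68 log units; beyond the scatter) against 5-(2-methoxyethoxy)-2-methylphenyl. Against 4-methylpyrimidin-5-yl the same ring gives a 1.3-fold lower number from compound 1 to compound 4 (0.10 log units; within the scatter) so the two aromatic groups no longer define the low end alone. Nothing measured here bears on the reason for this result. On these data alone, whether the number of compound 3 follows its aromatic ring or its 2-methoxyethoxy chain stays open. So does the effect of an amine or a hydroxyl on the cyclohexyl.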